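Aryl swap on the shared core, electroshock read-out

A few compounds are considered here, and "the series" means these few. Any claim that something is new, unique, unknown or untested is made for them only; others in the source may bear on it.

Measured so far:
compound 1 `CC(C(=O)N1CCN(c2ccccc2F)CC1)N1C(=O)CCC1=O` — 0%
compound 2 `CCC(C(=O)N1CCN(c2ccccc2F)CC1)N1C(=O)CCC1=O` — 0%

In a functional assay on the whole organism (strain Swiss) with Mus musculus as the target, in the maximal electroshock model, with a stated time of 2 h, at a dose of 100 mg/kg by the intraperitoneal route (on this read-out higher numbers stand for a stronger effect at the one dose given and lower numbers for a weaker effect), compound 1 gives 0% and compound 2 gives 0%. The one measured step, no change at the digits printed from compound 1 to compound 2 (within the scatter), alters a saturated chain carbon and leaves the read-out flat; compound 2 therefore stands level with compound 1 at the digits shown, both at the floor of this assay.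

Compound 3 `CCC(C(=O)N1CCN(c2cccc(C)c2)CC1)N1C(=O)CCC1=O` differs from compound 2 by 3-methylphenyl in place of 2-fluorophenyl on an amine nitrogen in a ring. Going by the values given here, no measured step touches the group on the amine nitrogen in the ring, so nothing speaks directly to this change. Among the compounds with values here, with both measured compounds at the floor and the only step flat, the expected step of no change at the digits printed from compound 2 to compound 3 (within the scatter) is none beyond the scatter, though an aryl change is untested here and the upper end is left open. Compound 3 is estimated at 0%, range 0% to 30%.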

Compound 3, a percentage reported as activity, at one dose (the size of the read-out at that dose, not a potency): 0%
The estimate for compound 3 equals the measured number at the digits printed; low and high end bracket the measured number.
By their numbers in this assay, from the lowest: compounds 1, 2 and 3 (each within the scatter of the next).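

In this assay, going by these compounds alone, the swap on the amine nitrogen in a ring gives no change at the digits printed from compound 2 to compound 3 (within the scatter) and so adds a first measured step at this position, where the earlier compounds spoke only to the saturated chain carbon. The entering 3-methylphenyl and the leaving 2-fluorophenyl have the same heavy-atom count and no hydrogen-bond donors or acceptors, and compound 3 at 0% remains level with the other two compounds. No supporting data bear on why this read-out stays flat.

With all three compounds at the floor, the series gives no direction for either position and cannot separate the two aryl groups from one another. Open, on these data alone, are a phenyl carrying chlorine or trifluoromethyl on the amine nitrogen in a ring, and a longer chain on the saturated chain carbon.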